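The compounds below may be only part of what the source reports. "The series", "measured", "known", "first", "only" and "open" are said of these compounds alone.

Measured compounds in a functional assay on CCRF-CEM cells (Homo sapiens) for cytotoxicity, with a stated time of 72 h; on this read-out lower numbers stand for stronger inhibition and higher numbers for weaker inhibition:
Compound 1 `O=C1/C(=C/c2ccccc2)CCC/C1=C\c1cccc([N+](=O)[O-])c1`: 2290 nM
Compound 2 `O=C1/C(=C/c2ccc(F)cc2)CCC/C1=C\c1ccccc1[N+](=O)[O-]`: 1510 nM

Of these two numbers, compound 1 holds the higher one, but the gap to compound 2 lies within the usual scatter, so the two compounds cannot be told apart on this read-out.

Compound 3 `CN(C)c1ccc(/C=C2\CCC/C(=C\c3cccc([N+](=O)[O-])c3)C2=O)cc1` has not yet been measured. It differs from compound 1 by dimethylamino in place of hydrogen on an aromatic carbon. Among the measured compounds shown here, no step between measured compounds describes this change, so the direction of its effect is unknown from the data at hand. With nothing to point either way, the expectation is a step of no more than the scatter, with a modest shift toward a lower number as the likelier outcome if any appears. The step from compound 1 to compound 3 is therefore estimated as a 1.5-fold lower number from compound 1 to compound 3 (0.18 log units; within the scatter). For compound 3 the expected value in this assay is 1500 nM, in a range from 500 nM to 5000 nM.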

Compound 3, half-maximal inhibitory concentration: 11700 nM
Estimate against measurement, compound 3: 7.8-fold (0.89 log units) below, outside the stated range (above it).
By their numbers in this assay, from the lowest: compounds 2 and 1 (each within the scatter of the next); then compound 3.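

Among the compounds shown here, this is the first single change that can be read in this assay: going from phenyl to 4-(dimethylamino)phenyl gives a 5.1-fold higher number from compound 1 to compound 3 (0.71 log units; beyond the scatter). The aromatic carbon para to a large group therefore does not tolerate every substituent equally, since this one group, with no ring and no net charge, shifts the read-out toward weaker inhibition by more than the scatter. Nothing in the data at hand explains this step.

From the compounds shown here alone, one group at one position gives no trend, and it remains open whether a primary amine, a methoxy group or a fluorine at the same place would shift the number in the same direction. Going by these compounds, it also remains open whether dimethylamino would have a comparable effect if the nitro group stood elsewhere on its ring.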